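The compounds below may be only part of what the source reports. "The series", "measured", "known", "first", "only" and "open" are said of these compounds alone.

Measured so far in a functional assay on MDA-MB-231 cells (Homo sapiens) for cytotoxicity, read by MTT assay, with a stated time of 48 h (on this read-out higher numbers stand for weaker inhibition and lower numbers for stronger inhibition), as follows:
- Compound 1 `Fc1cccc(-c2nc(Nc3ccccc3F)c3cc(F)ccc3n2)c1` gives > 50000 nM
- Compound 2 `Fc1cccc(-c2nc(Nc3cccc(Br)c3)c3cc(F)ccc3n2)c1` gives > 50000 nM
- Compound 3 `Oc1ccc(Nc2nc(-c3cccc(F)c3)nc3ccc(F)cc23)cc1` gives > 50000 nM

Each of these entries is a limit of the assay and not a number. Compound 3 stands at > 50000 nM as a limit, so it has no exact place on the scale. The same holds across the set, with the limit of > 50000 nM in this assay, at which 3 of the 3 values shown sit, as the whole picture so far.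

Compound 4 `Cc1ccccc1Nc1nc(-c2cccc(F)c2)nc2ccc(F)cc12` has 2-methylphenyl in place of 4-hydroxyphenyl on a nitrogen on an aromatic ring and keeps the shared core. Three measured changes at this same place bear on it: a step that the two limits leave unreadable from compound 1 to compound 2 and a step that the two limits leave unreadable from compound 1 to compound 3 and a step that the two limits leave unreadable from compound 2 to compound 3 in turn. None has a readable size, so they give no direction. Compound 1 carries 2-fluorophenyl at this place and shows > 50000 nM as a limit, so no clear gain is expected from the new group. The expected change is a number no higher from compound 3 to compound 4 (the limit leaves the size open) in this estimate, and another limit is the likeliest report. For compound 4 the estimated value is 50000 nM with an expected range from 20000 nM to 100000 nM in this assay here.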

Compound 4, half-maximal inhibitory concentration: > 50000 nM
Compound 4: no number, only a limit; the forecaster's own chance of this, stated with the estimate: 75%; the middle value sits exactly at the limit.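

Compound 4 also gives only a limit of the assay and not a number, so none of its steps from compound 1, compound 2 or compound 3 can be read. The compounds shown leave open whether the group on the nitrogen changes the result at all, and all of them share one limit: the limit of > 50000 nM in this assay, at which 4 of the 4 values shown sit.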